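Benzyl to aroyl on the five-membered ring nitrogen

The source may hold more compounds than are shown below. What is called first, only, known or untested is meant among the compounds shown, and "the series" means these compounds.

Compound 1 `Cc1ccc(CN2CCc3cc(NC(=O)NCc4ccncc4)ccc32)cc1` carries a 4-methylbenzyl on the five-membered ring nitrogen; in an assay on HEK293-A cells for activation of Nicotinamide phosphoribosyltransferase (Homo sapiens), tested at 1 uM (on this read-out higher numbers stand for a stronger effect at the one concentration tested and lower numbers for a weaker effect), compound 1 gives "not determined" (no result reported), so it stands on no number here. Compound 2 `Cc1ccc(C(=O)n2ccc3cc(NC(=O)NCc4ccncc4)ccc32)cc1`, an aromatic-ring analogue with the aroyl group, gives 44% in this assay. Compound 3 `Cc1ccc(C(=O)N2CCc3cc(NC(=O)NCc4ccncc4)ccc32)cc1` differs from compound 1 by (4-methylphenyl)carbonyl in place of 4-methylbenzyl on a nitrogen on an aromatic ring in a ring. With no value for compound 1, the size of the step to compound 3 in this assay cannot be put in numbers. Compound 3 is expected to give about 40% (range 10% to 70%) in this assay because compound 2 gives 44%.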

Compound 3, a percentage reported as activity, at one concentration (the size of the read-out at that concentration, not a potency): 25%
The estimate for compound 3 lay 15 percentage points above the measured number; the measured number falls inside the stated range.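

Among the compounds shown here, with no number for compound 1 in this assay, no step to compound 3 can be read. The compounds shown leave open how (4-methylphenyl)carbonyl compares with 4-methylbenzyl on this nitrogen. No evidence on hand bears on the result for compound 3.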